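This account rests on a few compounds, and the source may have more. Where it says the series, first, only, none or still open, it means among the compounds named here.

Measured so far in an assay on isolated protein for displacement of a labelled ligand from melanin-concentrating hormone receptor 1 (Homo sapiens); a lower number here means a stronger inhibitor, a higher number a weaker inhibitor:
compound 1 `CC(C)N(C)c1ccc2cc(NC(=O)CCc3ccc(C(F)(F)F)cc3)ccc2n1`: 2 nM
compound 2 `NC1CCN(c2ccc3cc(NC(=O)CCc4ccc(C(F)(F)F)cc4)ccc3n2)C1`: 12 nM
compound 3 `O=C(CCc1ccc(C(F)(F)F)cc1)Nc1ccc2nc(N3CCC(c4ccccc4)C3)ccc2c1`: 25 nM

Compound 3 stands at the highest of the three numbers. The gaps are a 2.1-fold higher number from compound 2 to compound 3 (0.32 log units; beyond the scatter) and a 13-fold higher number from compound 1 to compound 3 (1.10 log units; beyond the scatter), both beyond the scatter.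

Compound 4 `CN(c1ccc2cc(NC(=O)CCc3ccc(C(F)(F)F)cc3)ccc2n1)C1CCCC1` differs from compound 3 in one place: cyclopentyl(methyl)amino in place of 3-phenylpyrrolidin-1-yl on an aromatic carbon. The step that bears on this is a 13-fold higher number from compound 1 to compound 3 (1.10 log units; beyond the scatter), run in reverse: compound 1 carries isopropyl(methyl)amino at the same place and gives 2 nM in this assay. Cyclopentyl(methyl)amino resembles that group more than it does 3-phenylpyrrolidin-1-yl, so a large drop toward the number of compound 1 is expected, roughly a 6.3-fold lower number from compound 3 to compound 4 (0.80 log units; beyond the scatter). For compound 4 the expected value is 4 nM, with a range of 1.5 nM to 12 nM.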

Compound 4, half-maximal inhibitory concentration: 2 nM
For compound 4 the middle estimate is 2.0-fold (0.30 log units) above the measured one; low and high end bracket the measured number.
By their numbers in this assay, from the lowest: compounds 1 and 4 (each within the scatter of the next); then compound 2; then compound 3.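

In this assay cyclopentyl in place of isopropyl on the amine nitrogen is tolerated, with no change at the digits printed from compound 1 to compound 4 (within the scatter), so this position accepts a ring on that nitrogen as long as the methyl stays. Both pyrrolidine compounds stand apart from this pair, with a 13-fold lower number from compound 3 to compound 4 (1.10 log units; beyond the scatter) and a 6.0-fold lower number from compound 2 to compound 4 (0.78 log units; beyond the scatter), which separates cyclopentyl(methyl)amino from both 3-substituted pyrrolidin-1-yl groups. Nothing available explains these gaps.

Open, as far as these compounds go, is whether unsubstituted pyrrolidin-1-yl sides with compound 4 or with compound 2 and compound 3. Also open, from the compounds shown here alone, is how dimethylamino or cyclohexyl(methyl)amino would fare here.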